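Swapping the aryl group on the isoxazole of compound 1

The source may report more compounds than this note shows. Statements on the series, on what has been measured and on what is new or still open speak of the compounds shown alone.

Compound 1 `CCOC(=O)C1=Cc2ccccc2OC1(OCc1cc(-c2ccc(F)cc2F)no1)C(F)(F)F` carries a 2,4-difluorophenyl on its isoxazole ring. In a functional assay on A549 cells (Homo sapiens) for inhibition, read by MTT assay, with a stated time of 24 h (a higher number here means a weaker inhibitor, a lower number a stronger inhibitor), compound 1 reaches only the limit > 150000 nM, so for it only a limit is known, not a number (the limit of > 150000 nM in this assay, at which 1 of the 3 values shown sits). Two related compounds with a triazole instead of the isoxazole give numbers: compound 2 `CCOC(=O)C1=Cc2ccccc2OC1(OCc1cn(CC(=O)Nc2ccc(C)cc2)nn1)C(F)(F)F` gives 54300 nM in this assay, and compound 3 `CCOC(=O)C1=Cc2ccccc2OC1(OCc1cn(CC(=O)Nc2ccc(OC)cc2)nn1)C(F)(F)F` gives 29400 nM in this assay. Going by the values given here, the one measured step, a 1.8-fold lower number from compound 2 to compound 3 (0.27 log units; within the scatter), is within the scatter.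

Compound 4 `CCOC(=O)C1=Cc2ccccc2OC1(OCc1cc(-c2ccc(OC)cc2)no1)C(F)(F)F` differs from compound 1 by 4-methoxyphenyl in place of 2,4-difluorophenyl on an aromatic carbon. Among the compounds with values here, no measured step changes the same ring as this one; the only step available, a 1.8-fold lower number from compound 2 to compound 3 (0.27 log units; within the scatter), introduces a methoxy on a different aromatic ring and stays within the scatter. With compound 1 sitting at the limit, there is no number from which a step could be read, so compound 4 is expected to lie near the same limit, with the estimated step of an at least 1.1-fold lower number from compound 1 to compound 4 (0.06 log units; that floor lies within the scatter) not beyond the scatter. Compound 4 is thus expected to give about 130000 nM in this assay, with a range from 40000 nM to 400000 nM, and a real chance that only a limit is reported again.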

Compound 4, half-maximal inhibitory concentration: > 150000 nM
Compound 4: only a limit was reported (the forecaster's own chance of this, stated with the estimate: 55%); middle value at least 1.1-fold (0.06 log units) away from the limit.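

In this assay compound 4 gives > 150000 nM as a limit, not a number. Going by these compounds alone, compound 1 also reaches only a limit, so no step between compound 1 and compound 4 can be read. The compounds shown leave open what number either would give, and so whether 4-methoxyphenyl and 2,4-difluorophenyl differ at all, with both compounds at the same limit: the limit of > 150000 nM in this assay, at which 2 of the 4 values shown sit.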